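From methoxy to fluoro at the edge of a limit

The source may hold more compounds than are shown below. What is called first, only, known or untested is meant among the compounds shown, and "the series" means these compounds.

In an ADME assay on MT4 cells (Homo sapiens) for cytotoxicity, read by MTT assay (on this read-out higher numbers stand for lower toxicity in this test and lower numbers for higher toxicity in this test), compound 1 `Cc1ccc(CNC(=O)C2C(=O)N(O)C(=O)c3ccccc32)cc1` reads > 125000 nM, which is a limit of the assay and not a number. Compound 1 therefore stands at the limit of > 125000 nM in this assay, at which 1 of the 2 values shown sits. Within the data shown here, compound 2 `COc1ccc(CNC(=O)C2C(=O)N(O)C(=O)c3ccccc32)cc1` gives 119000 nM, the only actual number so far.

Among the measured compounds shown here, the single measured step, methoxy in place of methyl on an aromatic carbon, is an at least 1.0-fold lower number from compound 1 to compound 2 (0.02 log units; that floor lies within the scatter). Compound 3 `O=C(NCc1ccc(F)cc1)C1C(=O)N(O)C(=O)c2ccccc21` changes that same aromatic carbon again, with fluoro in place of methoxy on an aromatic carbon. The step from compound 1 is the only one that bears on this change, and it shows no movement beyond the scatter, although its size is only a floor. On that thin basis, no real shift is expected. In this assay the expected step is a 1.0-fold lower number from compound 2 to compound 3 (0.01 log units; within the scatter), which is estimated to stay within the scatter. Compound 3 is estimated at 115000 nM, with an expected range of 55000 nM to 200000 nM, and it may also be reported only as a limit.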

Compound 3, half-maximal cytotoxic concentration: 202000 nM
For compound 3 the middle estimate is 1.8-fold (0.24 log units) below the measured one; measured number outside the range, above it.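

In this assay, fluoro in place of methoxy on an aromatic carbon, para to a large group, gives a 1.7-fold higher number from compound 2 to compound 3 (0.23 log units; within the scatter). Among these compounds, this is the first step at this position whose full size can be read, as compound 2 and compound 3 both give actual numbers, and even this full step stays within the scatter, so the 4-methoxyphenyl to 4-fluorophenyl change shows no real effect on this read-out. Compound 1 gives a limit of the assay and not a number, so the step from compound 1 to compound 3 cannot be read: the limit of > 125000 nM in this assay, at which 1 of the 3 values shown sits.

What remains open is whether this position tolerates every kind of group, as an amine, a carboxylic acid or a longer chain at this aromatic carbon could still read differently from the methyl, methoxy and fluoro shown here. Also open, from the compounds shown here alone, is whether the shared core, and not the group at this position, sets the level of these readings, and the three compounds, which differ only at this one carbon, cannot settle that.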